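Swapping one amide group on a lipophilic compound

The source may report more compounds than this note shows. Statements on the series, on what has been measured and on what is new or still open speak of the compounds shown alone.

In a physicochemical assay for lipophilicity (a higher number here means a more lipophilic compound, a lower number a more polar compound), compound 1 (`CNC(=O)c1cc(C(=O)N[C@H]2[C@@H]3COC[C@@H]32)cc2c1O[C@H](CF)[C@H]2c1ccccc1`) reads 3.6 and compound 2 (`CNC(=O)c1cc(C(=O)N[C@H]2[C@@H]3COC[C@@H]32)c([C@@H](C)c2ccccc2)o1`) reads 4.1 on the same scale. Compound 2 is thus the higher of the two, by a gap beyond the usual scatter of repeat measurements. Compound 3 (`CNC(=O)c1cc(C(=O)N[C@H]2CC[C@H](O)CC2)c([C@@H](C)c2ccccc2)o1`) differs from compound 2 in one group on an amide-type nitrogen, and the change is this: a group of 7 heavy atoms (6 carbon, 1 oxygen; one six-membered non-aromatic ring of carbon only) in place of a group of 6 heavy atoms (5 carbon, 1 oxygen; one three-membered non-aromatic ring of carbon only, one five-membered non-aromatic ring with 1 hetero atom), on an amide-type nitrogen with the rest of the molecule untouched. Going by the values given here, no measured pair shows such a swap, so what follows is judgement alone. Starting from compound 2 at 4.1 as the only close reference, a small fall is expected, and it may not clear the scatter. The estimated change in this assay is a number 0.20 log units lower from compound 2 to compound 3 (within the scatter) and so a modest one. For compound 3 the expected value is 3.9 with a likely range from 3.5 to 4.3 once measured.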

Compound 3, distribution coefficient: 2.8
Estimate against measurement, compound 3: 1.10 log units above, and the stated range ends above it.
By their numbers in this assay, from the lowest: compound 3; then compound 1; then compound 2.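

The place on an amide-type nitrogen can move the reading strongly: in this assay the swap to 4-hydroxycyclohexyl leaves the reading a number 1.30 log units lower from compound 2 to compound 3 (beyond the scatter) with the rest of the molecule untouched. Going by these compounds alone, this is the first measured change at this place, and the step is large. The entering 4-hydroxycyclohexyl counts 1 hydrogen-bond donor and the group that leaves counts 0, but nothing available shows which difference between the two groups accounts for the step.

As far as these compounds go, it remains open how much of the step belongs to the hydroxyl and how much to the change of ring system, and a plain cyclohexyl group on the same nitrogen would separate the two. From the compounds shown here alone, a 4-methoxycyclohexyl or 4-aminocyclohexyl group there would show how the reading follows the atom attached to the ring, and it is also open whether the same swap on the core of compound 1 gives a similar step.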